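The compounds below may be only part of what the source reports. "The series", "measured", "known", "first", "only" and "open" are said of these compounds alone.

Working notes on the series. Among the measured compounds shown here, compound 1 `Cc1cc(-c2c(F)cc3c(=O)c(Cc4ccccc4N)cn(C4CC4)c3c2F)cc(C)n1` gives 2100 nM in a functional assay on P388 cells (Mus musculus) for cytotoxicity (on this read-out lower numbers stand for stronger inhibition and higher numbers for weaker inhibition), and stands lowest of the three numbers measured so far. Compound 2 `Cc1cc(-c2c(F)cc3c(=O)c(Cc4ccc(Cl)cc4)cn(C4CC4)c3c2F)cc(C)n1` gives 20000 nM and compound 3 `COc1cccc(Cc2cn(C3CC3)c3c(F)c(-c4cc(C)nc(C)c4)c(F)cc3c2=O)c1` gives 20000 nM; the values of compound 2 and compound 3 are within the scatter of each other. The two measured steps from compound 1 run the same way: a 9.5-fold higher number from compound 1 to compound 2 (0.98 log units; beyond the scatter) and a 9.5-fold higher number from compound 1 to compound 3 (0.98 log units; beyond the scatter), both beyond the scatter. Compound 4 `Cc1cc(-c2c(F)cc3c(=O)c(C(=O)O)cn(C4CC4)c3c2F)cc(C)n1` is not yet measured. It differs from compound 1 in carboxy in place of 2-aminobenzyl on an aromatic carbon. For the measured compounds named here, no measured step exchanges the 2-aminobenzyl for a group without a ring, so the two steps above bear on it only indirectly, in that any exchange of the 2-aminophenyl measured so far has given a higher number. A higher number is therefore expected for compound 4, and the loss of the whole benzyl is expected to cost at least as much as those exchanges did, estimated as a 14-fold higher number from compound 1 to compound 4 (1.15 log units; beyond the scatter). Compound 4 is estimated at 30000 nM, in a range of 8000 nM to 100000 nM, with a real chance that only a limit is reported.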

Compound 4, half-maximal inhibitory concentration: 29000 nM
Beside the measured number, compound 4's estimate is 1.0-fold (0.01 log units) above it, and the stated range covers the measured number.
By their numbers in this assay, from the lowest: compound 1; then compounds 2, 3 and 4 (each within the scatter of the next).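

In this assay, carboxy in place of 2-aminobenzyl on this aromatic carbon gives a 14-fold higher number from compound 1 to compound 4 (1.14 log units; beyond the scatter), so a group with no ring is now also seen to stand apart from compound 1. It does not separate from the two other benzyl groups, with a 1.5-fold higher number from compound 3 to compound 4 (0.16 log units; within the scatter) and a 1.5-fold higher number from compound 2 to compound 4 (0.16 log units; within the scatter), so among the four compounds only the 2-aminobenzyl of compound 1 stands apart at this position, while carboxy, 3-methoxybenzyl and 4-chlorobenzyl group together. Nothing measured on these compounds accounts for this difference.

The compounds shown leave open whether the amine or its place on the benzyl ring sets compound 1 apart, a question that an unsubstituted benzyl and a 4-aminobenzyl would address. As far as these compounds go, whether a 2-hydroxybenzyl would behave like the 2-aminobenzyl also remains open.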